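Swapping a Urea for a Phenyltriazole: Expected Stability

The compounds below may be only part of what the source reports. "The series", "measured", "known", "first", "only" and "open" are said of these compounds alone.

Of the compounds shown here, three have so far been measured in an ADME assay on microsomes from liver (Homo sapiens) for metabolic stability, read by LC-MS, with NADPH named in the record, with a stated time of 60 min, tested at 1 uM, in the absence of a further agent; a lower number here means that less of the compound is left, a higher number that more of the compound is left. Compound 1 `COc1ccc(-c2scc3c(N4CC[C@@H](NC(C)=O)C4)nc(C)nc23)cc1OC` is reported there only as a limit, > 95%. Compound 2 `COc1ccc(-c2c(C)nc3c(N4CC[C@@H](NC(C)=O)C4)cc(C)nn23)cc1F` likewise reaches the limit, giving > 95% in this assay. Compound 3 `COc1ccc(-c2c(C)nc3c(N4CC[C@@H](NC(=O)NC(C)C)C4)cc(C)nn23)cc1OC` stands at the same limit, with > 95% in this assay. Among the compounds with values here, in short, (the limit of > 95% in this assay, at which 3 of the 3 values shown sit), and no compound has yet given a number beneath it, so no step between measured compounds can be read from these data.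

Compound 4 `COc1ccc(-c2c(C)nc3c(N4CC[C@@H](n5cc(-c6ccccc6)nn5)C4)cc(C)nn23)cc1OC` has not been measured. It differs from compound 3 in one place: 4-phenyl-1H-1,2,3-triazol-1-yl in place of (isopropylcarbamoyl)amino on a saturated ring carbon. Within the data shown here, with no measured step to lean on, the expectation rests on the limit alone. The change is expected to reduce the fraction remaining by a modest amount, a step of a number at least 10 percentage points lower from compound 3 to compound 4 (that floor lies within the scatter) that would lie somewhat beyond the usual scatter, though a value once more at the limit cannot be ruled out. Compound 4 is therefore estimated at 85%, in a range from 55% to 98%.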

Compound 4, percent of the compound remaining: "unstable" (no number reported)
Compound 4: no number reported, and the estimate cannot be compared.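

Within the data shown here, no step between compound 3 and compound 4 can be read: in this assay compound 4 is recorded only as unstable, without a number, and compound 3 is reported only as a limit. The compounds shown leave open how much of compound 4 remains.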